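The source may report more compounds than this note shows. Statements on the series, on what has been measured and on what is new or still open speak of the compounds shown alone.

Measured in a toxicity assay on WI-38 cells (Homo sapiens) for inhibition, read by MTT assay, with a stated time of 48 h (on this read-out higher numbers stand for weaker inhibition and lower numbers for stronger inhibition), so far:
- Compound 1 `Cc1ccc(/C=C2\SC(=O)N(CCNC(=O)Nc3c(C)n(C)n(-c4ccccc4)c3=O)C2=O)cc1` gives 48100 nM
- Compound 2 `COc1cc(/C=C2\SC(=O)N(CCNC(=O)Nc3c(C)n(C)n(-c4ccccc4)c3=O)C2=O)cc(OC)c1OC` gives 51500 nM
- Compound 3 `Cc1ccc(/C=C2\SC(=O)N(CC(=O)Nc3c(C)n(C)n(-c4ccccc4)c3=O)C2=O)cc1` gives 83700 nM

Compound 3 at 83700 nM sits with compound 1 at 48100 nM and compound 2 at 51500 nM within the usual scatter, so these three cannot be ranked. The next compound, compound 4 `Cc1c(NC(=O)CN2C(=O)S/C(=C\c3ccc(Cl)cc3)C2=O)c(=O)n(-c2ccccc2)n1C`, keeps the rest of compound 3 and makes one change, from 4-methylphenyl to 4-chlorophenyl: chloro in place of methyl on an aromatic carbon.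

Going by the values given here, only one measured step alters this same group. It is a 1.1-fold higher number from compound 1 to compound 2 (0.03 log units; within the scatter), where 3,4,5-trimethoxyphenyl replaces 4-methylphenyl, and it stays within the scatter. Among the compounds with values here, no measured compound carries chloro, so the evidence is thin, but no step beyond the scatter is expected in this assay in either direction. The expected move is a 1.3-fold lower number from compound 3 to compound 4 (0.11 log units; within the scatter) and this estimate lies within the scatter. For compound 4 the estimated value is 65000 nM, with an expected range from 30000 nM to 125000 nM.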

Compound 4, half-maximal inhibitory concentration: 54400 nM
Compound 4: middle estimate off by 1.2-fold (0.08 log units), on the high side, within the range that was stated.
By their numbers in this assay, from the lowest: compounds 1, 2, 4 and 3 (each within the scatter of the next).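

In this assay, putting chloro in place of methyl on this aromatic carbon, para to a large group, gives a 1.5-fold lower number from compound 3 to compound 4 (0.19 log units; within the scatter), so this assay does not separate 4-chlorophenyl from 4-methylphenyl here. Together with a 1.1-fold higher number from compound 1 to compound 2 (0.03 log units; within the scatter), this means that the group has now been varied on two different chains, that of compound 1 and that of compound 3, and neither step goes beyond the scatter, with no compound shown going against this. Nothing measured here bears on why the two groups read alike.

Still open, as far as these compounds go, is whether an amine or a carboxylic acid on this aromatic carbon would give a step beyond the scatter. Also open, from the compounds shown here alone, is whether chloro would read the same on the chain of compound 1.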